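The source may report more compounds than this note shows. Statements on the series, on what has been measured and on what is new or still open speak of the compounds shown alone.

Three compounds share one core and were tested in a functional assay on P388 cells (Mus musculus) for antiproliferative activity, with a stated time of 72 h; on this read-out lower numbers stand for stronger inhibition and higher numbers for weaker inhibition. Compound 1 `C#CCSc1cnc2ccccc2c1[Se]CC#CCCl` gives 0.8 ug/mL. Compound 2 `CSc1cnc2ccccc2c1[Se]CC#CCOC(=O)/C=C/c1ccccc1` gives 43.9 ug/mL, and compound 3 `CCOC(=O)OCC#CCSc1c(SC)cnc2ccccc12` gives 34.7 ug/mL. Compound 1 therefore stands lowest of the three, and its gaps to compound 3 and to compound 2 both lie beyond the usual scatter of repeated measurements. For the measured compounds named here, compound 2 and compound 3 differ from compound 1 in more than one place, so no single step between measured compounds is available.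

Compound 4 `OCC#CCSc1cnc2ccccc2c1[Se]CC#CCCl` differs from compound 1 in one place only: hydroxymethyl in place of hydrogen on a triple-bonded carbon. The other chain on the core stays unchanged. Going by the values given here, nothing among the measured compounds shows how a change of this kind affects the result, so the expectation must rest on the nearness of compound 4 to compound 1. Compound 4 is expected to keep a number close to that of compound 1, with the step from compound 1 to compound 4 estimated at a 1.5-fold higher number from compound 1 to compound 4 (0.18 log units; within the scatter). Compound 4 is thus estimated at 1.2 ug/mL, with a likely range from 0.4 ug/mL to 4 ug/mL.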

Compound 4, concentration for 50% inhibition: 2 ug/mL
Compound 4: middle estimate off by 1.7-fold (0.22 log units), on the low side; low and high end bracket the measured number.
By their numbers in this assay, from the lowest: compound 1; then compound 4; then compounds 3 and 2 (each within the scatter of the next).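

Hydroxymethyl in place of hydrogen on a triple-bonded carbon gives the first direct reading of this position: in this assay the change produces a 2.5-fold higher number from compound 1 to compound 4 (0.40 log units; beyond the scatter), a modest step. The position therefore accepts this larger group at a modest cost, and the hydrogen on the triple-bonded carbon is not needed to keep the number in this low range. No measurement shown here bears on the reason for the rise.

As far as these compounds go, what an aminomethyl group or a longer chain on the same triple-bonded carbon would do to the number remains open. Also open, from the compounds shown here alone, is whether hydroxymethyl would give a step of similar size if the chlorine at the end of the other chain were replaced by an ester.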